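This account rests on a few compounds, and the source may have more. Where it says the series, first, only, none or still open, it means among the compounds named here.

Compound 2 `COc1ccccc1C(=O)NCc1ccc(CNS(=O)(=O)c2ccc(Cl)cc2)cc1` and compound 1 `COc1ccccc1C(=O)NCc1ccc(CNS(=O)(=O)c2cccc(Cl)c2)cc1` share one core and differ only in the chlorophenyl carried on the sulfonyl sulfur. Within the data shown here, in an assay on MDA-MB-231 cells for displacement of a labelled ligand from C-X-C chemokine receptor type 4 (Homo sapiens), read by fluorescence and microscopy, with stated times of 10 min and 30 min (a lower number here means that less compound is needed, a higher number that more compound is needed for the effect), compound 2 gives 1000 nM, and compound 1 gives 1000 nM, so compound 2 stands level with its only measured neighbour. Among the measured compounds shown here, the one step measured, no change at the digits printed from compound 1 to compound 2 (within the scatter), shows that exchanging one chlorophenyl for another at this point left the result unchanged within the scatter. Compound 3 `COc1ccccc1C(=O)NCc1ccc(CNS(=O)(=O)c2ccccc2Cl)cc1` is built from the same atoms, joined differently: 2-chlorophenyl in place of 4-chlorophenyl on a sulfonyl sulfur. For the measured compounds named here, the single measured step bears directly on this change. It too exchanged one chlorophenyl for another on the same sulfonyl sulfur, and it was flat. The expected outcome is therefore a step of no change at the digits printed from compound 2 to compound 3 (within the scatter), nothing beyond the scatter. Compound 3 is expected to give 1000 nM, within a range from 400 nM to 2500 nM.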

Compound 3, effective concentration (reported as EC, without a stated level of effect): 100 nM
Compound 3: middle estimate off by 10-fold (1.00 log units), on the high side, and the stated range ends above it.
By their numbers in this assay, from the lowest: compound 3; then compounds 1 and 2 (each within the scatter of the next).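

The position of the chlorine on this ring does matter, which the flat step between the first two compounds did not reveal. In this assay there is a 10-fold lower number from compound 2 to compound 3 (1.00 log units; beyond the scatter) and a 10-fold lower number from compound 1 to compound 3 (1.00 log units; beyond the scatter) when 2-chlorophenyl sits on the sulfonyl sulfur, with the heavy atoms counted for the group unchanged. Of these three arrangements, only the 2-chlorophenyl group stands apart, and no measurement is available here to explain the difference.

On these data alone, it remains open whether the chlorine itself is required: a plain phenyl, a 2-bromophenyl or a 2-methoxyphenyl group on the same sulfonyl sulfur could either keep the lower number or lose it. As far as these compounds go, it is also open whether the same change would give a similar step on a core with another group in place of the methoxy group.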